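Stereochemistry Swap in a Thiol Citrate Analogue

The source may report more compounds than this note shows. Statements on the series, on what has been measured and on what is new or still open speak of the compounds shown alone.

Measured so far:
compound 1, `O=C(O)C[C@@](O)(C(=O)O)[C@@H](Cl)C(=O)O`, 29000 nM
compound 2, `O=C(O)C[C@@](O)(C(=O)O)[C@H](S)C(=O)O`, 58000 nM

In an assay on isolated protein with ATP-citrate synthase (Rattus norvegicus) as the target (on this read-out higher numbers stand for weaker inhibition and lower numbers for stronger inhibition), compound 2 gives the higher of the two numbers, yet its gap to compound 1 lies within the scatter, so neither can be called the weaker. Compound 3, `O=C(O)C[C@@](O)(C(=O)O)[C@@H](S)C(=O)O`, has not been measured. It differs from compound 2 as follows: the two compounds have the same atoms and bonds and differ only in configuration as drawn: 1 of 2 stereo elements differ; a stereocentre at a saturated chain carbon is drawn S in compound 2 and R in compound 3. Among the measured compounds shown here, no measured pair shows how such a change in configuration alone plays out here, so no direction can be read from the data. Compound 3 is therefore expected to give 50000 nM, within 10000 nM to 300000 nM, a step of a 1.2-fold lower number from compound 2 to compound 3 (0.06 log units; within the scatter) that is estimated rather than known.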

Compound 3, inhibition constant: 150000 nM
Compound 3: the middle estimate sits 3.0-fold (0.48 log units) below what was measured; the range from low to high includes it.
By their numbers in this assay, from the lowest: compounds 1 and 2 (each within the scatter of the next); then compound 3.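

Drawing this saturated chain carbon R rather than S gives, in this assay, a 2.6-fold higher number from compound 2 to compound 3 (0.41 log units; beyond the scatter), and this weaker inhibition can be assigned to configuration alone, because nothing else separates the pair: the fact that compounds 2 and 3 differ only in the configuration as drawn

Sulfanyl in place of chloro on the same carbon gives a 5.2-fold higher number from compound 1 to compound 3 (0.71 log units; beyond the scatter), which leaves compound 3 the weakest of the three.

On these data alone, whether chloro responds to a change in configuration at this carbon as sulfanyl does remains open. So does the effect of a hydroxyl or an amine at this carbon.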